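The compounds below may be only part of what the source reports. "The series", "measured", "known", "first", "only" and "open" are said of these compounds alone.

Measured so far:
Compound 1 `CCC[C@@H]1NC(=O)[C@@H](CO)NC(=O)[C@@H](Cc2ccc(O)cc2)NCCOc2ccccc2/C=C/CNC1=O` — in an assay on isolated protein for displacement of a labelled ligand from Motilin receptor (Homo sapiens) (a lower number here means a stronger inhibitor, a higher number a weaker inhibitor), compound 1 gives > 10000 nM.
Compound 2 `CC(C)[C@H]1NC(=O)[C@@H](Cc2ccc(O)cc2)NCCOc2ccccc2/C=C/CNC(=O)[C@H](C)NC1=O` — in this assay compound 2 gives 1390 nM.
Compound 3 `CCC[C@@H]1NC(=O)[C@@H](C(C)C)NC(=O)[C@@H](CC2CCCCC2)NCCOc2ccccc2CCCNC1=O` — in this assay compound 3 gives 3250 nM.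

The value for compound 1 is a limit of this assay, not a number (the limit of > 10000 nM in this assay, at which 1 of the 3 values shown sits). Among the two numbers, compound 3 stands highest, and its gap to compound 2 is beyond the usual scatter.

Compound 4 `CCC[C@@H]1NC(=O)[C@@H](C(C)C)NC(=O)[C@@H](Cc2ccc3ccccc3c2)NCCOc2ccccc2CCCNC1=O` is not yet measured. It differs from compound 3 in one place: naphthalen-2-yl in place of cyclohexyl on a saturated chain carbon bound to a saturated ring carbon. For the measured compounds named here, with no measured step of this kind to lean on, a modest move to a lower number is expected, the step from compound 3 to compound 4 being a 2.2-fold lower number from compound 3 to compound 4 (0.34 log units; beyond the scatter). Compound 4 is therefore estimated at 1500 nM, within a range from 400 nM to 6000 nM.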

Compound 4, inhibition constant: 79 nM
Compound 4: middle estimate off by 19-fold (1.28 log units), on the high side; measured number outside the range, below it.
By their numbers in this assay, from the lowest: compound 4; then compound 2; then compound 3. At a limit, above all of these: compound 1.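

In this assay, naphthalen-2-yl in place of cyclohexyl gives a 41-fold lower number from compound 3 to compound 4 (1.61 log units; beyond the scatter). The earlier compounds shown here offered no single-place comparison, and this first one shows that the number is highly sensitive to the group carried at this chain carbon. Nothing measured here accounts for the size of this step. The compounds shown leave open whether a single phenyl ring would give a similar number, or whether the two aromatic rings are both needed. They also leave open how naphthalen-1-yl or an indole ring would compare at this place.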